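Pyrazole-carbonyl ureas: loss of the ring methyl

The source may hold more compounds than are shown below. What is called first, only, known or untested is meant among the compounds shown, and "the series" means these compounds.

The measured compounds and their numbers:
compound 1, `Cc1cnn(C(=O)N2CCCCC2)c1`, 1100 nM
compound 2, `O=C(N1CCCCC1)n1cccn1`, 5000 nM
compound 3, `Cc1cnn(C(=O)N(C)CCN(C)Cc2cccc(OCc3ccccc3)c2)c1`, 8300 nM

All three were tested in an assay on membranes from brain for binding affinity to Monoacylglycerol lipase ABHD6 (Mus musculus), read by fluorescence, with stated times of 1 h and 30 min; on this read-out higher numbers stand for weaker inhibition and lower numbers for stronger inhibition. Compound 1 and compound 2 share a core and differ in one place: hydrogen in place of methyl on an aromatic carbon. That change produced a 4.5-fold higher number from compound 1 to compound 2 (0.66 log units; beyond the scatter), so compound 2 is the weaker of the two.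

Compound 3 carries a different core, and the difference between the two cores is not broken down here. Its number is the highest of the three; against compound 2 it lies within the scatter, against compound 1 it lies beyond it.

Compound 4, `CN(CCN(C)C(=O)n1cccn1)Cc1cccc(OCc2ccccc2)c1`, has not yet been measured in this assay. It differs from compound 3 in one place: hydrogen in place of methyl on an aromatic carbon. This is the same kind of change as from compound 1 to compound 2. Around the place, the ring atom in compound 1 bears a group of 8 heavy atoms, while in compound 3 it bears a large group.

Because the same kind of change gave a 4.5-fold higher number from compound 1 to compound 2 (0.66 log units; beyond the scatter), compound 4 is expected to show a step of similar size, a 3.6-fold higher number from compound 3 to compound 4 (0.56 log units; beyond the scatter). The estimate for compound 4 is 30000 nM, expected between 10000 nM and 100000 nM, with some chance that only a limit is reported since compound 3 already starts high.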

Compound 4, half-maximal inhibitory concentration: 5500 nM
Beside the measured number, compound 4's estimate is 5.5-fold (0.74 log units) above it; the measured number lies below the stated range.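

In this assay, replacing the methyl with hydrogen in the 4-methyl-1H-pyrazol-1-yl to 1H-pyrazol-1-yl change on the larger core gives a 1.5-fold lower number from compound 3 to compound 4 (0.18 log units; within the scatter), so compound 3 and compound 4 cannot be told apart on this read-out. The step seen on the core of compound 1 therefore did not carry over in size to the core of compound 3, and the two cores answer differently to the same change: the same change on two cores in this assay, a 4.5-fold higher number (0.66 log units; beyond the scatter) from compound 1 to compound 2 and a 1.5-fold lower number (0.18 log units; within the scatter) from compound 3 to compound 4, 6.9-fold (0.84 log units) apart, beyond the scatter of two such steps

Among these compounds, this shows that, within these four compounds, the effect of the ring methyl depends on the core that carries it and cannot simply be transferred from one core to the other, but with only two pairs it neither gives a rule for the series nor explains why the two steps differ. The compounds shown leave open whether an ethyl group or a chlorine on the same aromatic carbon would follow the pattern of compound 1 and compound 2 or that of compound 3 and compound 4. They also leave open whether a core with a shorter chain, or one without the benzyl ether, would keep the methyl step seen on the smaller core.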